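Moving the fluorine on the triazole's phenyl group

This account rests on a few compounds, and the source may have more. Where it says the series, first, only, none or still open, it means among the compounds named here.

Measured compounds:
- compound 1, `COc1nc2ccc(Br)cc2cc1C(c1ccccc1)n1cc(-c2ccccc2)nn1`: 5.97%
- compound 2, `COc1nc2ccc(Br)cc2cc1C(c1ccccc1)n1cc(-c2ccccc2F)nn1`: 13.4%
- compound 3, `COc1nc2ccc(Br)cc2cc1C(c1ccccc1)n1cc(-c2ccc(OC(F)(F)F)cc2)nn1`: 21.6%

All three were tested in an ADME assay on PC-3 cells (Homo sapiens) for cytotoxicity, read by sulforhodamine B assay, with a stated time of 48 h, tested at 10 uM; on this read-out higher numbers stand for more inhibition at the one concentration tested (going by the name of the read-out) and lower numbers for less inhibition. Compound 2 stands in the middle of the three numbers: compound 1 sits a number 7.4 percentage points higher from compound 1 to compound 2 (within the scatter), and compound 3 sits a number 8.2 percentage points higher from compound 2 to compound 3 (within the scatter), so compound 2 is within the scatter of both neighbours. Among the measured compounds shown here, only the step from compound 1 to compound 3, a number 15.6 percentage points higher from compound 1 to compound 3 (beyond the scatter), is large enough to count.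

Compound 4, `COc1nc2ccc(Br)cc2cc1C(c1ccccc1)n1cc(-c2ccc(F)cc2)nn1`, differs from compound 2 only in the change (4-fluorophenyl in place of 2-fluorophenyl on an aromatic carbon). For the measured compounds named here, no measured step moves a fluorine from one place on this ring to another. The nearest guides are the fluoro-for-hydrogen step from compound 1 to compound 2 and the trifluoromethoxy-for-hydrogen step from compound 1 to compound 3, both pointing upward but only the second beyond the scatter. The step to compound 4 is therefore expected to stay within the scatter, with no clear direction, estimated as a number 0.6 percentage points higher from compound 2 to compound 4 (within the scatter). Compound 4 is expected to give about 14% in this assay, within a range from 3% to 26%.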

Compound 4, a percentage reported as inhibition, at one concentration (the size of the read-out at that concentration, not a potency): 16.4%
The estimate for compound 4 lay 2.4 percentage points below the measured number; the measured number falls inside the stated range.
By their numbers in this assay, from the lowest: compounds 1, 2, 4 and 3 (each within the scatter of the next, the first and the last beyond it).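

In this assay the switch from 2-fluorophenyl to 4-fluorophenyl gives a number 3 percentage points higher from compound 2 to compound 4 (within the scatter) and so shows no readable effect of where the fluorine sits on this ring. Compound 4 does add one thing: the fluoro-for-hydrogen change now gives a number 10.4 percentage points higher from compound 1 to compound 4 (beyond the scatter) and thus clears the scatter, which the same change in compound 2 did not. Replacing trifluoromethoxy with fluoro gives a number 5.2 percentage points lower from compound 3 to compound 4 (within the scatter) so the 4-(trifluoromethoxy)phenyl and 4-fluorophenyl groups cannot be told apart here either.

No measurement at hand explains why these numbers fall as they do. On these data alone, whether an amine or a carboxylic acid on this phenyl ring would move the number further stays open, as does how these compounds behave at any other concentration.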